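Moving Fluorines Around the Aryl Ring on the Piperazine Nitrogen

This account rests on a few compounds, and the source may have more. Where it says the series, first, only, none or still open, it means among the compounds named here.

Compound 2, `Nc1scc(CN2CCN(c3ccc(F)c(F)c3)CC2)c1C(=O)c1ccc(Cl)cc1`, gives -78% in a functional assay on CHO cells with adenosine receptor A1 (Homo sapiens) as the target, read by cAMP accumulation and immunoassay, with a stated time of 6 min, tested at 1 uM (a lower number here means a stronger effect, a higher number a weaker effect of the compound at the concentration tested), the lowest of the two numbers seen so far. Going by the values given here, compound 1, `Nc1scc(CN2CCN(c3ccncc3)CC2)c1C(=O)c1ccc(Cl)cc1`, gives -8.3% in this assay, and the only measured step, a number 69.7 percentage points lower from compound 1 to compound 2 (beyond the scatter), is a large one. Compound 3, `Nc1scc(CN2CCN(c3cccc(F)c3F)CC2)c1C(=O)c1ccc(Cl)cc1`, differs from compound 2 by 2,3-difluorophenyl in place of 3,4-difluorophenyl on an amine nitrogen in a ring. Among the compounds with values here, no measured step addresses this kind of change; the one step on record concerns a different exchange on the same ring nitrogen, so it bears only indirectly, indicating that the group on that nitrogen can shift the read-out strongly. Within the data shown here, with no direct precedent, the change from compound 2 to compound 3 is expected to produce a number 23 percentage points higher from compound 2 to compound 3 (beyond the scatter), a step toward a weaker effect that may or may not exceed the scatter. Compound 3 is therefore estimated at -55%, in the range -90% to -10%.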

Compound 3, a percentage reported as activity, at one concentration (the size of the read-out at that concentration, not a potency): -66%
The estimate for compound 3 lay 11 percentage points above the measured number; the measured number falls inside the stated range.
By their numbers in this assay, from the lowest: compound 2; then compound 3; then compound 1.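

Moving the two fluorines on the ring with no change in atoms is enough to alter the read-out in this assay, giving a number 12 percentage points higher from compound 2 to compound 3 (beyond the scatter), so the arrangement of the fluorines on this group matters as well as the group's identity. The 2,3-difluorophenyl group also stands far from pyridin-4-yl on the same ring nitrogen, with a number 57.7 percentage points lower from compound 1 to compound 3 (beyond the scatter), so among these three compounds both difluorophenyl groups give numbers well below that of compound 1, and none goes against this. Nothing available explains why the two fluorine arrangements differ.

The compounds shown leave open how an unsubstituted phenyl, 4-fluorophenyl or 2,4-difluorophenyl group would read on this nitrogen. They also leave open whether 3,4-dichlorophenyl or 3,4-dimethoxyphenyl would follow the 3,4-difluorophenyl group.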